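Trading trifluoromethyl for amino: which way will the number move?

The source may hold more compounds than are shown below. What is called first, only, known or untested is meant among the compounds shown, and "the series" means these compounds.

In an ADME assay on cells (Homo sapiens) for antiproliferative activity, read by MTT assay (a lower number here means a stronger inhibitor, a higher number a weaker inhibitor), compound 1 `O=C(N/N=C/c1ccccn1)c1ccc(O)cc1` gives > 80000 nM as its result, which is a limit of the assay and not a number. Compound 2 `O=C(NN=C(c1ccccn1)c1ccccn1)c1ccc(O)cc1` gives 7530 nM as a measured number, and compound 3 `O=C(N/N=C/c1ccccn1)c1ccc(C(F)(F)F)cc1` gives 22400 nM as the higher of the two measured numbers. Compound 4 `Nc1ccc(C(=O)N/N=C/c2ccccn2)cc1` has amino in place of trifluoromethyl on an aromatic carbon, a change counted as amino in place of trifluoromethyl on an aromatic carbon in its structure. Among the measured compounds shown here, the one measured step that bears on this is an at least 3.5-fold lower number from compound 1 to compound 3 (0.55 log units; beyond the scatter) on swapping hydroxy for trifluoromethyl; run backward, it suggests a higher number for compound 4, though amino is not hydroxy. An estimated 2.0-fold higher number from compound 3 to compound 4 (0.30 log units; within the scatter) is therefore expected as a modest rise. The estimate for compound 4 is 45000 nM with an expected range from 18000 nM to 110000 nM across repeated measurements.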

Compound 4, half-maximal inhibitory concentration: > 80000 nM
Compound 4: no number, only a limit; the forecaster's own chance of this, stated with the estimate: 35%; middle value at least 1.7-fold (0.24 log units) away from the limit.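

Amino in place of trifluoromethyl gives, in this assay and on the same aromatic carbon, an at least 3.5-fold higher number from compound 3 to compound 4 (0.55 log units; beyond the scatter) and so joins hydroxy as a second group that leaves the number higher than trifluoromethyl does at this place. Compound 4 gives a limit of the assay and not a number: the limit of > 80000 nM in this assay, at which 2 of the 4 values shown sit.

The step between hydroxy and amino cannot be read, and these two groups stay unranked. On these data alone, whether a chlorine atom or a methyl group at this place would keep a measurable number remains open.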